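Methoxy to trifluoromethoxy: expected read-out for compound 3

This account rests on a few compounds, and the source may have more. Where it says the series, first, only, none or still open, it means among the compounds named here.

Compound 1 `Nc1scc(CN2CCN(c3ccc(F)cc3Cl)CC2)c1C(=O)c1ccc(Cl)cc1` and compound 2 `COc1ccc(N2CCN(Cc3csc(N)c3C(=O)c3ccc(Cl)cc3)CC2)cc1` share one core and differ only in the group on the amine nitrogen in the ring. In a functional assay on CHO cells with adenosine receptor A1 (Homo sapiens) as the target, read by cAMP accumulation and immunoassay, with a stated time of 6 min, tested at 0.01 uM (a lower number here means a stronger effect, a higher number a weaker effect of the compound at the concentration tested), compound 1 gives 6.1%, and compound 2 gives -1.2%; the step of a number 7.3 percentage points lower from compound 1 to compound 2 (within the scatter) is within the scatter. Compound 2 thus stands at the low end of the two numbers, though its gap to compound 1 is within the scatter. Compound 3 `Nc1scc(CN2CCN(c3ccc(OC(F)(F)F)cc3)CC2)c1C(=O)c1ccc(Cl)cc1` is not yet measured and differs from compound 2 by trifluoromethyl in place of methyl on an oxygen on an aromatic ring. For the measured compounds named here, no measured step touches the group on this oxygen; the only step known, a number 7.3 percentage points lower from compound 1 to compound 2 (within the scatter), swapped the whole ring on the amine nitrogen and moved the read-out within the scatter. A step of a number 3.2 percentage points higher from compound 2 to compound 3 (within the scatter) within the scatter is therefore expected. Compound 3 is estimated in this assay at 2%, with a range from -10% to 14%.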

Compound 3, a percentage reported as activity, at one concentration (the size of the read-out at that concentration, not a potency): 0%
Compound 3: the middle estimate sits 2 percentage points above what was measured; measured number inside the range.
By their numbers in this assay, from the lowest: compounds 2, 3 and 1 (each within the scatter of the next).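

In this assay, for the compounds shown here, the step of a number 1.2 percentage points higher from compound 2 to compound 3 (within the scatter) is the first measured change to the group on this oxygen, and trifluoromethyl in place of methyl on an oxygen on an aromatic ring leaves compound 2 and compound 3 indistinguishable. The step of a number 6.1 percentage points lower from compound 1 to compound 3 (within the scatter) shows that 4-(trifluoromethoxy)phenyl and 2-chloro-4-fluorophenyl on the amine nitrogen in a ring cannot be told apart in this read-out either. No supporting data bear on why these read-outs lie so close together.

The read-out gives the size of the effect at the one concentration tested, and at that concentration no stronger or weaker effect can be assigned among compound 1, compound 2 and compound 3. Going by these compounds, it also remains open whether a longer chain on the oxygen, or an amine or a carboxylic acid in place of the trifluoromethoxy group, would move the read-out beyond the scatter.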